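Acetyl for Hydroxyethyl on a Cytotoxicity Read-out

A few compounds are considered here, and "the series" means these few. Any claim that something is new, unique, unknown or untested is made for them only; others in the source may bear on it.

Compound 1 `CC(O)c1ccc(C(=O)N[C@@H](C)Cn2ccc(-c3ccc(C#N)c(Cl)c3)n2)cc1`: > 30000 nM
Compound 2 `CC(=O)c1ccc(C(=O)N[C@@H](C)Cn2ccc(-c3ccc(C#N)c(Cl)c3)n2)cc1`: > 30000 nM
Compound 3 `CC(Cn1ccc(-c2ccc(C#N)c(Cl)c2)n1)C(=O)Nc1cccc(C(C)O)c1`: > 30000 nM

Of the compounds shown here, three have been measured in an ADME assay on PC-3 cells (Homo sapiens) for cytotoxicity, read by CCK-8 assay, with a stated time of 6 days (on this read-out lower numbers stand for stronger inhibition and higher numbers for weaker inhibition), and a fourth, compound 4 `CC(=O)c1cccc(NC(=O)C(C)Cn2ccc(-c3ccc(C#N)c(Cl)c3)n2)c1`, has not. In this assay compound 1 gives > 30000 nM, which is a limit of the assay and not a number. Compound 2 likewise gives > 30000 nM, again a limit. Compound 3 gives > 30000 nM, also a limit.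

From compound 1 to compound 2 the change is acetyl in place of 1-hydroxyethyl on an aromatic carbon, and the step it made is a step that the two limits leave unreadable from compound 1 to compound 2, since (the limit of > 30000 nM in this assay, at which 3 of the 3 values shown sit). How the core of compound 1 and the core of compound 3 differ is not broken down here. From compound 3 to compound 4 the change is acetyl in place of 1-hydroxyethyl on an aromatic carbon, the same kind of change, though the place differs: para to a large group in the first pair, meta to a large group in the second.

Resting only on the unreadable step that the two limits leave unreadable from compound 1 to compound 2 and the fact that all three values sit at the limit, the step from compound 3 to compound 4 is expected to be about a step that the limit leaves unreadable from compound 3 to compound 4. Compound 4 is therefore estimated at 40000 nM, most likely reported as a limit again, between 15000 nM and 120000 nM.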

Compound 4, half-maximal inhibitory concentration: > 30000 nM
Compound 4: no number, only a limit; the forecaster's own chance of this, stated with the estimate: 85%; the middle value does not contradict the limit.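

In this assay compound 4 gives > 30000 nM, which is a limit of the assay and not a number. No step can be read from compound 3 to compound 4, because the result stops at the same limit: the limit of > 30000 nM in this assay, at which 4 of the 4 values shown sit. The compounds shown leave open what acetyl in place of 1-hydroxyethyl does to the value in either place.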